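Lactone in place of the methoxy-amide side chain

The compounds below may be only part of what the source reports. "The series", "measured", "known", "first", "only" and "open" are said of these compounds alone.

Measured so far in a physicochemical assay for lipophilicity, read by HPLC, at pH 7.5; a higher number here means a more lipophilic compound, a lower number a more polar compound:
compound 1 `CCOc1ccccc1-c1ccc(-c2nc3cnccc3c(NC(COC)C(N)=O)c2C#N)cc1` gives 2.8
compound 2 `CC(Nc1c(C#N)c(-c2ccc(Br)cc2)nc2cnccc12)C(N)=O` gives 2.1
compound 3 `CC[C@@H](Nc1c(C#N)c(-c2ccc(-c3cccc(OC)c3)cc2)nc2cnccc12)C(N)=O` gives 2.7

Compound 1 carries the top number of the three in this assay. Compound 3 stands closest, a gap that lies within the scatter of repeated measurements, so the two cannot be told apart on these numbers. Compound 2 stands furthest, and its gap to compound 1 is beyond the scatter. Within the data shown here, no two of these measured compounds differ in one place only, so no single step between them is available, and nothing can be said about how any part of the shared core moves the read-out.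

Compound 4 `CCOc1ccccc1-c1ccc(-c2nc3cnccc3c(N[C@@H]3CCOC3=O)c2C#N)cc1` has not yet been measured. It differs from compound 1 in one place:

2-oxooxolan-3-yl in place of 1-carbamoyl-2-methoxyethyl on a nitrogen on an aromatic ring

The group that leaves carries one hydrogen-bond donor; the group that enters carries none, with the same count of acceptors and one heavy atom fewer, closed into a five-membered non-aromatic ring. For the step in this assay an upward move is expected, of a size near the edge of the scatter: a number 0.40 log units higher from compound 1 to compound 4 (beyond the scatter).

Compound 4 is therefore expected to give 3.2 in this assay, with a range from 2.7 to 3.7.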

Compound 4, distribution coefficient: 2.7
For compound 4 the middle estimate is 0.50 log units above the measured one; the range from low to high includes it.
By their numbers in this assay, from the lowest: compound 2; then compounds 3, 4 and 1 (each within the scatter of the next).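

Notes on the side chain on the nitrogen on an aromatic ring: this pair gives the first single-place step of the series, and in this assay the exchange of 1-carbamoyl-2-methoxyethyl for 2-oxooxolan-3-yl reads (a number 0.10 log units lower from compound 1 to compound 4 (within the scatter)). A group with 1 hydrogen-bond donor and no ring gives way here to one with 0 hydrogen-bond donors and a five-membered non-aromatic ring, and the read-out does not tell compound 1 and compound 4 apart, so at this position, on this core, the exchange leaves no difference that can be resolved. Nothing at hand accounts for this result.

Open, going by these compounds, is whether the reading holds for this one pair only, since the same exchange on the 4-bromophenyl core of compound 2 or the 3-methoxyphenyl core of compound 3 would test it on a different core. Also open, on these data alone, is how this assay responds at this nitrogen to a five-membered lactam with nitrogen in place of the ring oxygen, to a free carboxylic acid, or to the opposite configuration at the defined stereocentre of compound 4.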